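Series notes: cyclopropyl in place of methyl

A few compounds are considered here, and "the series" means these few. Any claim that something is new, unique, unknown or untested is made for them only; others in the source may bear on it.

Compound 2 `CC(c1ccc(-c2ccsc2)nc1)n1ccnc1` gives 151 nM in an in vitro assay on V79MZh cells for inhibition of cytochrome P450 11B2, mitochondrial (Homo sapiens); a lower number here means a stronger inhibitor, a higher number a weaker inhibitor. For the measured compounds named here, compound 1 `CC(c1ccc(-c2ccccc2)nc1)n1ccnc1` gives 200 nM in this assay; the step of a 1.3-fold lower number from compound 1 to compound 2 (0.12 log units; within the scatter) lies within the scatter, so the two cannot be ordered on these numbers, and compound 2 simply holds the lowest of the two numbers with compound 1 as its only neighbour. Compound 3 `c1cn(C(c2ccc(-c3ccsc3)nc2)C2CC2)cn1` differs from compound 2 by cyclopropyl in place of methyl on a saturated chain carbon bound to an aromatic carbon and an aromatic nitrogen. Going by the values given here, no measured step touches this change: the one step in hand, from compound 1 to compound 2, puts thiophen-3-yl in place of phenyl on an aromatic carbon and leaves the saturated chain carbon untouched, and it was itself within the scatter. There is therefore no basis in the data for a step of any size in this assay in either direction, and the expectation is no change beyond the scatter, which is what the estimated step of a 1.2-fold lower number from compound 2 to compound 3 (0.07 log units; within the scatter) expresses. For compound 3 the estimate is 130 nM, with an expected range from 40 nM to 450 nM.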

Compound 3, half-maximal inhibitory concentration: 31 nM
Beside the measured number, compound 3's estimate is 4.2-fold (0.62 log units) above it; the measured number lies below the stated range.
By their numbers in this assay, from the lowest: compound 3; then compounds 2 and 1 (each within the scatter of the next).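

For the compounds shown here, the saturated chain carbon bound to an aromatic carbon and an aromatic nitrogen is a position that responds in this assay: cyclopropyl in place of methyl gives a 4.9-fold lower number from compound 2 to compound 3 (0.69 log units; beyond the scatter), whereas the only earlier step, thiophen-3-yl in place of phenyl on an aromatic carbon, stayed within the scatter. The change that moves the number here is purely a carbon one, since the entering cyclopropyl brings a three-membered ring of carbon only, with no hydrogen-bond donors or acceptors and no net charge, so a larger all-carbon group on this chain carbon is tolerated with thiophen-3-yl on the core. Nothing at hand accounts for why the number falls with this change.

As far as these compounds go, whether the step depends on the ring itself or only on the added carbons stays open, as an ethyl or isopropyl group on this carbon would be needed to separate the two, and a cyclobutyl group or a longer chain would show how far the trend runs. From the compounds shown here alone, it also stays open whether cyclopropyl gives a step of similar size with phenyl in place of thiophen-3-yl, as in the core of compound 1.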